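The source may hold more compounds than are shown below. What is called first, only, known or untested is meant among the compounds shown, and "the series" means these compounds.

Compound 2 (`COc1ccc(/C=C\c2cc(OC)c(OC)c(OC)c2)cc1OCc1ccc(CN2CC[C@H](O)C2)cc1`) was tested in an ADME assay on HEK293 cells (Homo sapiens) for cytotoxicity, read by CCK-8 assay, with a stated time of 48 h (on this read-out higher numbers stand for weaker inhibition and lower numbers for stronger inhibition), where compound 2 gives > 50000 nM, which is a limit of the assay and not a number. Compound 1 (`COc1ccc(/C=C\c2cc(OC)c(OC)c(OC)c2)cc1OCc1ccc(CNC(C)(C)C(=O)O)cc1`) gives > 50000 nM in this assay, and this too is a limit. So the measurements amount to the limit of > 50000 nM in this assay, at which 2 of the 2 values shown sit, and compound 2 has no number of its own to stand on.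

Compound 3 (`COc1ccc(/C=C\c2cc(OC)c(OC)c(OC)c2)cc1OCc1ccc(CNCCN(C)C)cc1`) carries (2-(dimethylamino)ethyl)amino in place of 3-hydroxypyrrolidin-1-yl on a saturated chain carbon bound to an aromatic carbon. Within the data shown here, the one measured step that bears on this place is a step that the two limits leave unreadable from compound 1 to compound 2, so it gives no size to carry over. Nothing measured points to a step beyond the scatter in this assay, in either direction, and a further limit is the likeliest result. The step expected is an at least 1.1-fold lower number from compound 2 to compound 3 (0.04 log units; that floor lies within the scatter), an estimate that carries no firm direction. For compound 3 the estimated value is 45000 nM, with an expected range from 15000 nM to 100000 nM.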

Compound 3, half-maximal inhibitory concentration: 39000 nM
The estimate for compound 3 lay 1.2-fold (0.06 log units) above the measured number, and the stated range covers the measured number.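

In this assay, among these compounds, compound 3 gives 39000 nM, which makes it the first compound here with a number rather than a limit for a group at this place, on a saturated chain carbon bound to an aromatic carbon. Putting (2-(dimethylamino)ethyl)amino in place of 3-hydroxypyrrolidin-1-yl gives an at least 1.2-fold lower number from compound 2 to compound 3 (0.10 log units; that floor lies within the scatter), and the same compound read against the carboxylic acid gives an at least 1.2-fold lower number from compound 1 to compound 3 (0.10 log units; that floor lies within the scatter), so neither step can be said to go beyond the scatter, and neither has a fixed size, as each starts from a limit. This change therefore shows no firm shift at this place, only that the open chain with two nitrogens can be given a number, while most of the series still rests on a limit: the limit of > 50000 nM in this assay, at which 2 of the 3 values shown sit.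

The compounds shown leave open whether a longer chain between the two nitrogens, a diethylamino end group or a piperazine at this place would give a value clearly apart from that of compound 3. They also leave open whether the ring or the second nitrogen of the entering group matters, as the change alters both at once.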